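Replacing 3-methylphenyl with 1-methyl-1H-indol-6-yl

This account rests on a few compounds, and the source may have more. Where it says the series, first, only, none or still open, it means among the compounds named here.

- Compound 1 `C=Cc1ccc(-c2cc3nccc(-c4cc(OC)c(OC)c(OC)c4)n3n2)cc1`: 193 nM
- Compound 2 `COc1cc(-c2ccnc3cc(-c4cccc(C)c4)nn23)cc(OC)c1OC`: 1080 nM

In a functional assay on MCF7 cells (Homo sapiens) for inhibition, read by CCK-8 assay, with a stated time of 48 h (a lower number here means a stronger inhibitor, a higher number a weaker inhibitor), compound 2 has the higher of the two numbers, at 1080 nM. Compound 3 `COc1cc(-c2ccnc3cc(-c4ccc5ccn(C)c5c4)nn23)cc(OC)c1OC` carries 1-methyl-1H-indol-6-yl in place of 3-methylphenyl on the same aromatic carbon: 1-methyl-1H-indol-6-yl in place of 3-methylphenyl on an aromatic carbon. Within the data shown here, only one measured step changes the group at this place: a 5.6-fold higher number from compound 1 to compound 2 (0.75 log units; beyond the scatter). Among the measured compounds shown here, it shows that a swap here can move the number modestly, but no measured compound carries the incoming group. A step of similar size toward a lower number in this assay is therefore expected, with low confidence. The expected move is a 3.1-fold lower number from compound 2 to compound 3 (0.49 log units; beyond the scatter). For compound 3 the estimated value is 350 nM, with an expected range from 50 nM to 1500 nM.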

Compound 3, half-maximal inhibitory concentration: 74 nM
For compound 3 the middle estimate is 4.7-fold (0.67 log units) above the measured one; the range from low to high includes it.
By their numbers in this assay, from the lowest: compound 3; then compound 1; then compound 2.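

In this assay, 1-methyl-1H-indol-6-yl gives a 15-fold lower number from compound 2 to compound 3 (1.16 log units; beyond the scatter), a larger step than any seen before at this aromatic carbon. It also gives a 2.6-fold lower number from compound 1 to compound 3 (0.42 log units; beyond the scatter), so compound 3 has the lowest number of the three and a two-ring group is tolerated here. The compounds shown leave open whether the methyl on the indole nitrogen or the second ring matters, which an indole with a free nitrogen-hydrogen or a naphthyl group could separate. No measurement shown explains the size of these steps.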